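Pyridin-3-yl anilide replacement in the chloropyridine piperazine series

A few compounds are considered here, and "the series" means these few. Any claim that something is new, unique, unknown or untested is made for them only; others in the source may bear on it.

In an assay on cells for agonist activity at D(4) dopamine receptor (Homo sapiens), read by luminescence and beta-arrestin recruitment, with a stated time of 90 min (a lower number here means that less compound is needed, a higher number that more compound is needed for the effect), compound 1 `CCc1cccc(NC(=O)CN2CCN(c3ccccn3)CC2)c1` gives 133 nM. Compound 2 `Cc1cccc(NC(=O)CN2CCN(c3ccc(Cl)cn3)CC2)c1` differs from compound 1 in two places; in this assay compound 2 gives "not active" (no number reported), so no single number fixes where compound 2 stands; it is simply recorded as inactive. Compound 3 `O=C(CN1CCN(c2ccc(Cl)cn2)CC1)Nc1cccnc1` awaits measurement; its change from compound 2 is pyridin-3-yl in place of 3-methylphenyl on an amide-type nitrogen. Among the compounds with values here, no step between measured compounds bears on this change, so its size is unfixed. Since compound 2 gives no number, compound 3 is expected to stay weak, with a real chance that this assay again reports no value. Compound 3 is estimated at 4000 nM, within 800 nM to 20000 nM.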

Compound 3, half-maximal effective concentration: "not active" (no number reported)
Compound 3 has no reported number here, and the estimate cannot be compared.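

In this assay compound 2 and compound 3 both stay without a number, so no step can be read between them, and no evidence bears on this result. Going by these compounds, what pyridin-3-yl in place of 3-methylphenyl does to potency stays open.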